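Compound 3: removing the pyridin-2-yl group from compound 2

This account rests on a few compounds, and the source may have more. Where it says the series, first, only, none or still open, it means among the compounds named here.

For the measured compounds named here, in a functional assay on ECa-109 cells (Homo sapiens) for antiproliferative activity, read by MTT assay, with a stated time of 48 h (a lower number here means a stronger inhibitor, a higher number a weaker inhibitor), compound 1 `Cn1cc(C2=C(c3nn(CCn4ccnc4)c4ncccc34)C(=O)N(c3ccccc3)C2=O)c2ccccc21` gives 8770 nM and compound 2 `Cn1cc(C2=C(c3nn(CCCN4CCCCC4)c4ncccc34)C(=O)N(c3ccccn3)C2=O)c2ccccc21` gives 7300 nM, so compound 2 stands within the scatter of the only other measured number. Compound 3 `Cn1cc(C2=C(c3nn(CCCN4CCCCC4)c4ncccc34)C(=O)NC2=O)c2ccccc21` follows from compound 2 with hydrogen in place of pyridin-2-yl on an amide-type nitrogen in a ring. Going by the values given here, no measured pair isolates this change, so the expectation is loose: a moderate move toward a lower number in this assay. The expected change is a 1.8-fold lower number from compound 2 to compound 3 (0.26 log units; within the scatter). The estimate for compound 3 is 4000 nM, with an expected range of 1200 nM to 14000 nM.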

Compound 3, half-maximal inhibitory concentration: 42300 nM
Estimate against measurement, compound 3: 11-fold (1.02 log units) below; measured number above the stated range.
By their numbers in this assay, from the lowest: compounds 2 and 1 (each within the scatter of the next); then compound 3.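

In this assay, for the compounds shown here, the pyridin-2-yl group on the amide-type nitrogen in a ring gives way to hydrogen with a 5.8-fold higher number from compound 2 to compound 3 (0.76 log units; beyond the scatter) as the first single-place step. At this position, then, the substituent matters, and the bare amide hydrogen is the poorer of the two. No available measurement accounts for this step.

Going by these compounds, whether the pyridin-2-yl ring itself or any group here supports activity remains open, since phenyl appears only in compound 1, which differs from compound 2 elsewhere too. Methyl or benzyl on this nitrogen would help separate these readings.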